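The source may hold more compounds than are shown below. What is called first, only, known or untested is meant among the compounds shown, and "the series" means these compounds.

Measured so far in a functional assay on HepG2 cells (Homo sapiens) for inhibition, read by MTT assay, with a stated time of 72 h; on this read-out lower numbers stand for stronger inhibition and higher numbers for weaker inhibition:
compound 1 `COc1cc(/C=C/C(=O)c2c(O)cc(O)cc2OC)cc(OC)c1` gives 17600 nM
compound 2 `COc1cc(/C=C/C(=O)c2c(O)cc(O)cc2OC)cc(OC)c1OC` gives 20400 nM
compound 3 `COc1cc(/C=C/C(=O)c2c(OC)cc(OC)cc2OC)cc(OC)c1` gives 9000 nM

Compound 4 `COc1cc(OC)c(C(=O)/C=C/c2cc(OC)c(OC)c(OC)c2)c(OC)c1` has not been measured. The cores of compound 1 and compound 3 differ, and that difference is not broken down here. Compound 4 differs from compound 3 by methoxy in place of hydrogen on an aromatic carbon and compound 2 differs from compound 1 by methoxy in place of hydrogen on an aromatic carbon; the two place descriptions agree word for word, so the change is the same. That change gave a 1.2-fold higher number from compound 1 to compound 2 (0.06 log units; within the scatter). For compound 4 the step from compound 3 is expected to be of similar size, a 1.2-fold higher number from compound 3 to compound 4 (0.07 log units; within the scatter), because compound 1 to compound 2 showed a 1.2-fold higher number from compound 1 to compound 2 (0.06 log units; within the scatter). Compound 4 is therefore estimated at 10500 nM. For compound 4 the expected range runs from 5000 nM to 22000 nM.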

Compound 4, half-maximal inhibitory concentration: 16500 nM
Beside the measured number, compound 4's estimate is 1.6-fold (0.20 log units) below it, and the stated range covers the measured number.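

In this assay, methoxy in place of hydrogen on an aromatic carbon gave a 1.8-fold higher number from compound 3 to compound 4 (0.26 log units; within the scatter) on the core of compound 3. Set beside the earlier step, this shows the change carrying over between the two cores, with no difference that can be told apart: the same change on two cores in this assay, a 1.2-fold higher number (0.06 log units; within the scatter) from compound 1 to compound 2 and a 1.8-fold higher number (0.26 log units; within the scatter) from compound 3 to compound 4, 1.6-fold (0.20 log units) apart, within the scatter of two such steps.
This does not show that the change is without effect in general, as it rests on two pairs in one assay, and a small effect or a small dependence on the core cannot be resolved from steps of this size.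

The compounds shown leave open whether an amine, a carboxylic acid or a longer chain at this place would give a step beyond the scatter. As far as these compounds go, whether the methoxy step holds on any further core also stays open.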